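Triazole N-chain variation on the dichlorophenyl amide series

This account rests on a few compounds, and the source may have more. Where it says the series, first, only, none or still open, it means among the compounds named here.

Measured so far:
compound 1 `Cn1c(Cc2nn(C)c(=O)c3ccccc23)nnc1SCC(=O)Nc1ccc(Cl)cc1Cl` — 7700 nM
compound 2 `CCOC(CCn1c(Cc2nn(C)c(=O)c3ccccc23)nnc1SCCCCCCCC(=O)Nc1ccc(Cl)cc1Cl)OCC` — > 30000 nM
compound 3 `Cn1nc(Cc2nnc(SCCCCCCCC(=O)Nc3ccc(Cl)cc3Cl)n2CCC=O)c2ccccc2c1=O` — 960 nM

In an assay on NK92 cells for inhibition of interleukin-2 (Homo sapiens), read by AlphaScreen, with stated times of 30 min and 1 h (a lower number here means a stronger inhibitor, a higher number a weaker inhibitor), compound 1 gives 7700 nM, the highest of the two numbers shown. The nearest number belongs to compound 3, which gives 960 nM. Compound 2 reaches only a limit of the assay, (the limit of > 30000 nM in this assay, at which 1 of the 3 values shown sits), and so returns no number. Among the measured compounds shown here, the one step measured within one change, an at least 31-fold lower number from compound 2 to compound 3 (1.49 log units; beyond the scatter), shows that what sits on the chain carbon next to the aromatic nitrogen of the shared core can move the read-out strongly, though it was measured on the long-linker pair and not on the short linker of compound 1.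

Compound 4 `Cn1nc(Cc2nnc(SCC(=O)Nc3ccc(Cl)cc3Cl)n2CCCO)c2ccccc2c1=O` differs from compound 1 by 2-hydroxyethyl in place of hydrogen on a saturated chain carbon bound to an aromatic nitrogen. For the measured compounds named here, the only step that bears on this is the same-position change from compound 2 to compound 3, which was large; nothing shows how such a chain behaves on the short-linker core. The step is therefore expected to be moderate, toward a lower number, but not confidently beyond the scatter: compound 4 is estimated at 4000 nM, between 1200 nM and 13000 nM, which means an expected 1.9-fold lower number from compound 1 to compound 4 (0.28 log units; within the scatter).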

Compound 4, half-maximal inhibitory concentration: > 30000 nM
Compound 4: a limit, no number; the forecaster's own chance of this, stated with the estimate: 5%; at least 7.5-fold (0.87 log units) between middle value and limit.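

On the short-linker core, 2-hydroxyethyl in place of hydrogen on a saturated chain carbon bound to an aromatic nitrogen gives an at least 3.8-fold higher number from compound 1 to compound 4 (0.59 log units; beyond the scatter) in this assay, so extending this chain can cost activity here. Compound 4 gives > 30000 nM, which is a limit of the assay, so the step has a lower bound and no measured size: the limit of > 30000 nM in this assay, at which 2 of the 4 values shown sit. The earlier step, an at least 31-fold lower number from compound 2 to compound 3 (1.49 log units; beyond the scatter), showed only a gain from changing the chain end on the long linker; this position can also move the number upward on the short linker.

From the compounds shown here alone, it remains open whether the loss follows the added carbons or the hydroxyl. A plain propyl chain or a 3-aminopropyl chain at this place on the short-linker core would separate the two.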